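The source may hold more compounds than are shown below. What is called first, only, known or untested is meant among the compounds shown, and "the series" means these compounds.

Compound 3 `Cc1c(O)nc(SC(C)C)nc1C(C)c1c(F)cccc1F` was tested for its toxicity to cells in an ADME assay on MT4 cells (Homo sapiens) for activation, read by MTT assay; a lower number here means that less compound is tolerated, a higher number that more compound is tolerated. There compound 3 gives > 3000 nM, which is a limit of the assay and not a number. Compound 1 `CCCSc1nc(Cc2c(F)cccc2Cl)c(C)c(=O)[nH]1` gives > 76000 nM, also a limit. Compound 2 `CCCSc1nc(C(CC)c2c(F)cccc2Cl)c(C)c(=O)[nH]1` gives > 3000 nM, again a limit. Compound 4 `CCC(C)Sc1nc(O)c(C)c(C(C)c2c(F)cccc2F)n1` differs from compound 3 by one small change: methyl in place of hydrogen on a saturated chain carbon, two bonds along the chain from a sulfur. This turns isopropylsulfanyl into (sec-butyl)sulfanyl. Among the compounds with values here, the only measured step is a step that the two limits leave unreadable from compound 1 to compound 2, and it lies at another place in the molecule, so it offers no size to carry over. No step beyond the usual scatter is therefore expected. The expected size of a step that the limit leaves unreadable from compound 3 to compound 4 remains a rough estimate. For compound 4 the estimated value is 20000 nM, with an expected range from 3000 nM to 100000 nM.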

Compound 4, half-maximal cytotoxic concentration: > 3000 nM
Compound 4 gave a limit, no number (the forecaster's own chance of this, stated with the estimate: 80%); the middle value lies beyond the limit too.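

Compound 3 and compound 4 each give only a limit, and no size can be read for the step between them. Open remains how much of either compound is tolerated, and whether isopropylsulfanyl and (sec-butyl)sulfanyl differ at all.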